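This account rests on a few compounds, and the source may have more. Where it says the series, first, only, none or still open, it means among the compounds named here.

In a physicochemical assay for solubility, read by spectrophotometry, in phosphate buffer, with a stated time of 2 h, at pH 7.4 (a higher number here means a more soluble compound, a lower number a less soluble compound), compound 1 `COc1ccc2[nH]c(C(=O)N3CC(=O)N(Cc4ccccc4)[C@@H](CN4CCC(C)CC4)C3)cc2c1` gives 93100 nM. Compound 2 `COc1ccc2[nH]c(C(=O)N3CC(=O)N(Cc4ccccc4)[C@@H](CN4CCC(OC)CC4)C3)cc2c1` is reported only as a limit of this assay, namely > 25000 nM. The step that the limit leaves unreadable from compound 1 to compound 2 cannot be sized, because compound 2 sits at the limit of > 25000 nM in this assay, at which 1 of the 3 values shown sits. Among the compounds with values here, compound 3 `COc1cccc(CN2C(=O)CN(C(=O)c3cc4cc(OC)ccc4[nH]3)C[C@@H]2c2ccccc2)c1`, which carries a phenyl on the same carbon and a methoxy on its benzyl group, gives 13600 nM in this assay; no single-change step connects it to compound 2, so its value stands on its own.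

Compound 4 `COc1ccc2[nH]c(C(=O)N3CC(=O)N(Cc4ccccc4)[C@@H](N4CCc5ccccc54)C3)cc2c1` has not yet been measured. It differs from compound 2 in one place: 2,3-dihydro-1H-indol-1-yl in place of (4-methoxypiperidin-1-yl)methyl on a saturated ring carbon. Within the data shown here, none of the measured steps covers this exchange, and the one step that touches the same carbon, from compound 1 to compound 2, is unreadable. Among the measured compounds shown here, the only numbers to lean on are the readable values of compound 1 and compound 3, which span a modest spread in this assay with different groups on that carbon. For compound 4 the expected value in this assay is 15000 nM, with a range from 5000 nM to 45000 nM. The step of an at least 1.6-fold lower number from compound 2 to compound 4 (0.22 log units; that floor lies within the scatter) that this estimate implies is expected to be small against a starting point that is itself only a limit.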

Compound 4, solubility: 7000 nM
For compound 4 the middle estimate is 2.1-fold (0.33 log units) above the measured one; the range from low to high includes it.
By their numbers in this assay, from the lowest: compounds 4 and 3 (each within the scatter of the next); then compound 1.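

In this assay, within the data shown here, compound 4 gives the first readable change at this saturated ring carbon: replacing (4-methylpiperidin-1-yl)methyl with 2,3-dihydro-1H-indol-1-yl brings a 13-fold lower number from compound 1 to compound 4 (1.12 log units; beyond the scatter), a large step. Making the same exchange from the (4-methoxypiperidin-1-yl)methyl group gives an at least 3.5-fold lower number from compound 2 to compound 4 (0.55 log units; beyond the scatter), so the number also falls beyond the scatter with this second departing group, and the two piperidine-bearing compounds agree in direction. That second size is only a floor, and the earlier step into compound 2 cannot be read, because compound 2 stands at a limit and not at a number: the limit of > 25000 nM in this assay, at which 1 of the 4 values shown sits.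

The exchange alters two things at once, since the entering group sits directly on the ring carbon and brings an aromatic ring, while the departing groups reach the carbon through a methyl link and have a saturated ring, so the compounds shown leave open which of these goes with the lower number. A piperidin-1-yl group set directly on this carbon, or a (2,3-dihydro-1H-indol-1-yl)methyl group, would pull these two apart.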